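This account rests on a few compounds, and the source may have more. Where it says the series, first, only, none or still open, it means among the compounds named here.

Compound 2 `OCc1nc2cc(NCc3ccccc3OCc3ccccc3)ccc2[nH]1` carries a hydroxymethyl on the shared core, and a close relative, compound 1 `NCc1nc2cc(NCc3ccccc3OCc3ccccc3)ccc2[nH]1`, carries an aminomethyl in the same position. In an assay on isolated protein for inhibition of matrix metalloproteinase-9 (Mus musculus) (a lower number here means a stronger inhibitor, a higher number a weaker inhibitor), compound 1 gives 13000 nM; 13000 nM; 13000 nM (3 entries). In this assay compound 2 returns only a limit, > 100000 nM, and no single number. Compound 2 thus stands at the limit of > 100000 nM in this assay, at which 1 of the 2 values shown sits, so its place among the two values shown is known only as a limit.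

The next step takes compound 2 to compound 3 `CC(=O)NCc1nc2cc(NCc3ccccc3OCc3ccccc3)ccc2[nH]1`, and the change is acetamido in place of hydroxy on a saturated chain carbon bound to an aromatic carbon, which amounts to hydroxymethyl becoming acetamidomethyl. Within the data shown here, no measured pair in this set shares this change, so the size of the step can only be guessed from the two values at hand. The acetamido keeps a hydrogen-bond donor and a hydrogen-bond acceptor where the hydroxy had them, so compound 3 is expected to stay weak, though it may come back into the measurable range. Compound 3 is estimated at 60000 nM, within 15000 nM to 200000 nM. The expected step is an at least 1.6-fold lower number from compound 2 to compound 3 (0.22 log units; that floor lies within the scatter), toward stronger inhibition but uncertain.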

Compound 3, half-maximal inhibitory concentration: > 100000 nM
Compound 3: only a limit was reported (the forecaster's own chance of this, stated with the estimate: 45%); middle value at least 1.6-fold (0.22 log units) from the limit.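

In this assay compound 3 returns only a limit, > 100000 nM, so no step from compound 2 can be read, since both compounds end at the same limit: the limit of > 100000 nM in this assay, at which 2 of the 3 values shown sit.

The compounds shown leave open how far beyond that limit compound 2 and compound 3 lie, and whether the two differ at all.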